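A few compounds are considered here, and "the series" means these few. Any claim that something is new, unique, unknown or untested is made for them only; others in the source may bear on it.

Measured compounds, antiproliferative read-out at a single concentration:

compound 1 `COc1ccc(/C=N/NC(=O)c2cc(OC)c(OC)c(OC)c2)c(OC)c1`: -6.9%
compound 2 `COc1cc(C2=NN(C(C)=O)C(c3ccc(F)c(F)c3)O2)cc(OC)c1OC`: 18.3%
compound 3 `COc1cccc(/C=N/NC(=O)c2cc(OC)c(OC)c(OC)c2)c1OC`: -0.1%

In a functional assay on BGC-823 cells (Homo sapiens) for antiproliferative activity, read by MTT assay, tested at 1 uM (on this read-out lower numbers stand for a weaker effect and higher numbers for a stronger effect at the one concentration tested), compound 2 gives 18.3%, the highest of the three numbers. The nearest is compound 3 at -0.1%, lower by a margin beyond the scatter; the furthest is compound 1 at -6.9%, lower by a still larger margin, also beyond the scatter. Compounds 1 and 3 share a hydrazone framework unlike the core of compound 2, so only compound 2 informs the next step.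

Compound 4 `COc1cc(C2=NN(C(C)=O)C(c3cccc(C(F)(F)F)c3)O2)cc(OC)c1OC` is the not yet measured analogue. It differs from compound 2 as follows: 3-(trifluoromethyl)phenyl in place of 3,4-difluorophenyl on a saturated ring carbon. Both groups carry fluorine on a single six-membered aromatic ring of carbon only, with no donors or acceptors and no charge either way. Going by the values given here, no step between measured compounds bears on such a swap, so the step is expected to be small, within the scatter, with no direction to favour; the expected step is a number 0.3 percentage points lower from compound 2 to compound 4 (within the scatter). For compound 4 in this assay the estimate is 18%, expected within 4% to 32%.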

Compound 4, a percentage reported as inhibition, at one concentration (the size of the read-out at that concentration, not a potency): 27.9%
Compound 4: the middle estimate sits 9.9 percentage points below what was measured, and the stated range covers the measured number.
By their numbers in this assay, from the lowest: compounds 1 and 3 (each within the scatter of the next); then compounds 2 and 4 (each within the scatter of the next).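

Going by these compounds alone, on the saturated ring carbon of the shared core, this assay gives the first direct comparison at this position: 3-(trifluoromethyl)phenyl in place of 3,4-difluorophenyl is a number 9.6 percentage points higher from compound 2 to compound 4 (within the scatter). The position therefore takes either fluorine-bearing phenyl group, and this read-out at its single concentration does not separate the two. No measurement at hand bears on why the two groups read as they do.

Still open, going by these compounds, is whether the position holds its read-out without fluorine, as with a plain phenyl, or with a phenyl carrying a dimethylamino group or a carboxylic acid. Also open, on these data alone, is whether the ring atom that bears an acetyl group would tolerate a longer chain such as butanoyl, and how either group reads across a range of concentrations.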